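Thioester series: 2-hydroxyethyl in place of benzyl at sulfur

A few compounds are considered here, and "the series" means these few. Any claim that something is new, unique, unknown or untested is made for them only; others in the source may bear on it.

Measured compounds:
compound 1 `CC1(C)CC(=O)C(C(=S)SCCO)=C(Nc2ccc(Cl)cc2)C1` — > 20 ug/mL
compound 2 `CC1(C)CC(=O)C(C(=S)SCc2ccccc2)=C(Nc2ccc(Br)cc2)C1` — > 20 ug/mL

In a functional assay on PBMC cells (Homo sapiens) for inhibition, read by ELISA, with a stated time of 18 h (a higher number here means a weaker inhibitor, a lower number a stronger inhibitor), compound 1 returns only a limit of the assay, not a number: > 20 ug/mL. Compound 2 likewise returns only a limit there, > 20 ug/mL. Compound 2 thus stands at the limit of > 20 ug/mL in this assay, at which 2 of the 2 values shown sit, and the values shown do not separate it from compound 1. Compound 3 `CC1(C)CC(=O)C(C(=S)SCCO)=C(Nc2ccc(Br)cc2)C1` is the next member: it keeps the aniline of compound 2 and changes the thioester side, (hydroxymethyl in place of phenyl on a saturated chain carbon bound to a sulfur). Within the data shown here, no step between measured compounds is available for this change. Compound 1 already carries the (2-hydroxyethyl)sulfanyl group and sits at the same limit as compound 2, so no shift beyond the scatter is expected from the change, and the step from compound 2 to compound 3 in this assay is estimated as a step that the limit leaves unreadable from compound 2 to compound 3. Compound 3 is expected to read near 30 ug/mL, within 12 ug/mL to 100 ug/mL, most likely again as a limit.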

Compound 3, half-maximal inhibitory concentration: > 20 ug/mL
Compound 3: no number, only a limit; the forecaster's own chance of this, stated with the estimate: 85%; the middle value is on the limit's open side.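

The steps from compound 1 and compound 2 to compound 3 cannot be read in this assay, since all three compounds return only a limit: the limit of > 20 ug/mL in this assay, at which 3 of the 3 values shown sit.

The compounds shown leave open whether hydroxymethyl in place of phenyl, or bromo in place of chloro, shifts inhibition in this assay at all.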